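Three Sulfonamides at the Limit and a Fourth to Test

The source may report more compounds than this note shows. Statements on the series, on what has been measured and on what is new or still open speak of the compounds shown alone.

Measured so far:
- compound 1 `CC1CCN(C2CCN(S(=O)(=O)c3ccc(OCc4ccccc4)cc3)CC2)CC1` gives > 5000 nM
- compound 2 `CCCC(=O)N(Cc1ccccc1)C1CCN(S(=O)(=O)c2c(C)cc(C)cc2C)CC1` gives > 5000 nM
- compound 3 `Cc1cc(Cl)cc(Cl)c1S(=O)(=O)N1CCC(N2CCC(C)CC2)CC1` gives > 5000 nM

All three compounds were tested in an ADME assay on HCT-116 cells (Homo sapiens) for cytotoxicity, read by CellTiter-Glo, with a stated time of 72 h (a higher number here means a weaker inhibitor, a lower number a stronger inhibitor), which reports the concentration of a compound needed to inhibit the growth signal of the cells. For compound 1 the reading of > 5000 nM is a limit of the assay, not a number: the compound did not reach half-maximal inhibition within the tested range. The same holds for compound 2 and for compound 3, each sitting at the limit of the assay. This is summarised by the observation that (the limit of > 5000 nM in this assay, at which 3 of the 3 values shown sit). Nothing in the measured set therefore separates one compound from another; where compound 1 stands can only be said as "not measurably toxic up to the limit".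

Compound 4 `COc1ccc(-c2ccc(S(=O)(=O)N3CCC(N4CCC(C)CC4)CC3)cc2)cc1` differs from compound 1 in one place: 4-methoxyphenyl in place of benzyloxy on an aromatic carbon. Going by the values given here, no measured pair shows what such a rearrangement of the same atoms does to cytotoxicity, so no step size can be taken from the data. The expectation for compound 4 is that it behaves like the three measured compounds and, in this assay, most likely again returns only a limit, with a change of a step that the limit leaves unreadable from compound 1 to compound 4 expected to stay within the scatter. Compound 4 is estimated at 8000 nM, with a likely range from 3000 nM to 30000 nM.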

Compound 4, half-maximal inhibitory concentration: > 5000 nM
Compound 4: a limit, no number; the forecaster's own chance of this, stated with the estimate: 80%; the middle value does not contradict the limit.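

Going by these compounds alone, compound 1 and compound 4 each rest at a limit of the assay rather than at a number, so no step between them can be read. All the compounds shown stand at the same point in this assay: the limit of > 5000 nM in this assay, at which 4 of the 4 values shown sit. From the compounds shown here alone, what stays open is whether 4-methoxyphenyl in place of benzyloxy changes cytotoxicity at all.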